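Trifluoromethyl in place of methyl on the shared core

The source may report more compounds than this note shows. Statements on the series, on what has been measured and on what is new or still open speak of the compounds shown alone.

Values in a functional assay on A549 cells (Homo sapiens) for inhibition; on this read-out higher numbers stand for weaker inhibition and lower numbers for stronger inhibition:
Compound 1 `COc1ccc(/C=C/c2ccc3ccccc3c2)cc1`: > 5000 nM, a limit
Compound 2 `Cc1ccc(/C=C/c2ccc3ccccc3c2)cc1`: > 5000 nM, a limit

Compound 2 stands only at a limit, > 5000 nM in this assay, so it offers no number to move from. Compound 3 `FC(F)(F)c1ccc(/C=C/c2ccc3ccccc3c2)cc1` differs from compound 2 in one place: trifluoromethyl in place of methyl on an aromatic carbon. Within the data shown here, the one measured step that bears on this change is a step that the two limits leave unreadable from compound 1 to compound 2, and it gives no size to carry over. What remains is the limit of > 5000 nM in this assay, at which 2 of the 2 values shown sit. On that basis, compound 3 is also expected to read out as a limit more often than as a number, and no direction can be assigned with confidence. The expected change is a step that the limit leaves unreadable from compound 2 to compound 3, which is only a rough estimate. For compound 3 the estimated value is 6000 nM. The estimated range for compound 3 runs from 2000 nM to 15000 nM.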

Compound 3, half-maximal inhibitory concentration: > 5000 nM
Compound 3: only a limit was reported; the forecaster's own chance of this, stated with the estimate: 70%; the middle value does not contradict the limit.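

Among these compounds, compound 3 gives > 5000 nM in this assay, a limit and not a number, so no step among compound 1, compound 2 and compound 3 can be read. The compounds shown leave open how methoxy, methyl and trifluoromethyl on the shared core rank in this assay.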